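The compounds below may be only part of what the source reports. "The series", "measured", "known", "first", "only" and "open" are said of these compounds alone.

Measured so far in a functional assay on HCT-116 cells (Homo sapiens) for antiproliferative activity, read by MTT assay, with a stated time of 48 h; a higher number here means a weaker inhibitor, a lower number a stronger inhibitor:
Compound 1 `O=C(/C=C/c1cccc(Cl)c1)c1nc2ccccc2s1`: > 100000 nM (a limit of the assay)
Compound 2 `O=C(/C=C/c1ccccn1)c1nc2ccccc2[nH]1`: 60 nM

Going by the values given here, compound 2 holds the only actual number, at 60 nM, so it cannot yet be ranked against another number. Compound 1 gives only a limit, > 100000 nM. Among the compounds with values here, no two measured compounds differ in just one place, so no measured step is available as a guide.

The next compound is compound 3 `O=C(/C=C/c1ccncc1)c1nc2ccccc2[nH]1`, which has the same atoms as compound 2, joined differently: pyridin-4-yl in place of pyridin-2-yl on a double-bonded chain carbon bound to a double-bonded chain carbon. The change places pyridin-4-yl in place of pyridin-2-yl on a double-bonded chain carbon bound to a double-bonded chain carbon.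

Within the data shown here, with no measured step to scale from, the expectation in this assay is only tentative. Compound 2 reads low at 60 nM, so a move towards weaker inhibition is thought more likely than a gain. The expected change is a 3.3-fold higher number from compound 2 to compound 3 (0.52 log units; beyond the scatter), a moderate loss with wide uncertainty. The estimate for compound 3 is 200 nM, with an expected range of 40 nM to 1500 nM.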

Compound 3, half-maximal inhibitory concentration: 710 nM
Beside the measured number, compound 3's estimate is 3.6-fold (0.55 log units) below it, and the stated range covers the measured number.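

In this assay, pyridin-4-yl in place of pyridin-2-yl on a double-bonded chain carbon bound to a double-bonded chain carbon gives a 12-fold higher number from compound 2 to compound 3 (1.07 log units; beyond the scatter), the first single-place step available in the series. The two groups have the same atoms and the same counts of hydrogen-bond donors and acceptors, so this position distinguishes between two pyridine isomers, and the reading depends on how the group is joined and not only on its composition. Nothing measured here accounts for the size of the step.

The compounds shown leave open whether pyridin-3-yl or an unsubstituted phenyl ring at the same chain carbon would read closer to compound 2 or to compound 3, which would show whether the step belongs to pyridin-2-yl or to pyridin-4-yl. Going by these compounds alone, also open is whether the same step would hold with an amine or a methoxy group on the pyridine ring, since a single pair gives only one step at this position.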